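This account rests on a few compounds, and the source may have more. Where it says the series, first, only, none or still open, it means among the compounds named here.

Measured so far:
compound 1, `Nc1cc(N)c2nc(-c3ccccc3)c(Oc3ccc(Cl)c(Cl)c3)nc2c1`: 20900 nM
compound 3, `CCOC(=O)[C@H](CCC(=O)O)NC(=O)c1ccc(Sc2nc3cc(N)cc(N)c3nc2-c2ccccc2)cc1`: 33900 nM
compound 2, `CCOC(=O)[C@H](CCC(=O)O)NC(=O)c1ccc(CNc2nc3cc(N)cc(N)c3nc2-c2ccccc2)cc1`: < 100000 nM

In a functional assay on MDA-MB-435 cells (Homo sapiens) for inhibition, read by sulforhodamine B assay, with a stated time of 48 h (a lower number here means a stronger inhibitor of growth, a higher number a weaker inhibitor of growth), compound 1 gives 20900 nM. Compound 3 gives 33900 nM in this assay; the two numbers lie within the scatter of each other, so no order between compound 1 and compound 3 can be read. For compound 2 the result < 100000 nM is a limit of the assay and not a number (the limit of < 100000 nM in this assay, at which 1 of the 3 values shown sits). Compound 1 therefore stands beside the one other number shown, with nothing beyond the scatter separating the pair.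

Compound 4, `Nc1cc(N)c2nc(-c3ccccc3)c(Oc3ccc(F)cc3)nc2c1`, differs from compound 1 in one place: 4-fluorophenyl in place of 3,4-dichlorophenyl on an oxygen on an aromatic ring. For the measured compounds named here, no measured pair covers this change, so the step rests on the structural difference alone. The step from compound 1 to compound 4 is expected to be small, a 1.4-fold higher number from compound 1 to compound 4 (0.16 log units; within the scatter), in the direction of a weaker inhibitor or none beyond the scatter. Compound 4 is estimated at 30000 nM in this assay, with a range from 10000 nM to 90000 nM.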

Compound 4, concentration for total growth inhibition: 32400 nM
Estimate against measurement, compound 4: 1.1-fold (0.03 log units) below; the measured number falls inside the stated range.
By their numbers in this assay, from the lowest: compounds 1, 4 and 3 (each within the scatter of the next).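

In this assay, the change of 3,4-dichlorophenyl to 4-fluorophenyl on an oxygen on an aromatic ring gives a 1.6-fold higher number from compound 1 to compound 4 (0.19 log units; within the scatter). For the compounds shown here, this is the first pair that differs in one place, and it shows that this exchange, 3,4-dichlorophenoxy to 4-fluorophenoxy, does not separate the two compounds in this assay. Nothing measured here speaks to a cause for this step.

On these data alone, whether this position tolerates more than halogen exchange stays open: a phenyl ring carrying an amine or a nitrile in place of the halogens, or a longer chain between the oxygen and the ring, could still move the number beyond the scatter. Going by these compounds alone, compounds 2 and 3 differ from compound 1 and compound 4 in more than one place, so no single step links them to this pair.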